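Trading iodo for trifluoromethyl after a flat step

The source may report more compounds than this note shows. Statements on the series, on what has been measured and on what is new or still open speak of the compounds shown alone.

Compound 1 `OCc1cn(Cc2cccc(F)c2)c2ccccc12`: 20 nM
Compound 2 `OCc1cn(Cc2cccc(I)c2)c2ccccc12`: 20 nM

In a functional assay on T29Kt1 cells (Homo sapiens) for cytotoxicity, read by sulforhodamine B assay, with a stated time of 3 days (a higher number here means a weaker inhibitor, a lower number a stronger inhibitor), compound 2 gives 20 nM, level with compound 1. Compound 3 `OCc1cn(Cc2cccc(C(F)(F)F)c2)c2ccccc12` makes one further change, trifluoromethyl in place of iodo on an aromatic carbon. Within the data shown here, only one measured step bears on this, no change at the digits printed from compound 1 to compound 2 (within the scatter), which also exchanged one group on that carbon for another. Among the measured compounds shown here, no trifluoromethyl compound has been measured yet, so this is thin evidence. Going by that single step, no change beyond the scatter is expected in this assay. The estimated step is no change at the digits printed from compound 2 to compound 3 (within the scatter). Compound 3 is expected at 20 nM, with an estimated range of 8 nM to 50 nM.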

Compound 3, half-maximal inhibitory concentration: 560 nM
For compound 3 the middle estimate is 28-fold (1.45 log units) below the measured one, and the stated range ends below it.
By their numbers in this assay, from the lowest: compounds 1 and 2 (each within the scatter of the next); then compound 3.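

On the aromatic carbon where fluoro and iodo gave no difference, trifluoromethyl brings a 28-fold higher number from compound 2 to compound 3 (1.45 log units; beyond the scatter) and a 28-fold higher number from compound 1 to compound 3 (1.45 log units; beyond the scatter) in this assay. This position therefore does respond to the group it carries, and the flat step between the first two compounds did not mean that any group is tolerated there. Nothing available explains why trifluoromethyl parts from fluoro and iodo in this way. The compounds shown leave open whether other groups on this carbon, such as methyl, methoxy or an amine, stay level with fluoro and iodo or weaken the compound as trifluoromethyl does.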